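The compounds below may be only part of what the source reports. "The series", "measured", "known", "first", "only" and "open" are said of these compounds alone.

In a functional assay on PC-3 cells (Homo sapiens) for antiproliferative activity, read by MTT assay, with a stated time of 48 h (on this read-out lower numbers stand for stronger inhibition and higher numbers for weaker inhibition), compound 1 (`COc1ccc(CN(C(=O)CSc2nc3ccccc3s2)c2cc(OC)c(OC)c(OC)c2)cc1`) gives 8460 nM, compound 2 (`COc1ccc(CN(C(=O)CSc2nc3ccccc3s2)c2cc(OC)c(OC)c(OC)c2)cc1O`) gives 2110 nM and compound 3 (`COc1ccc2nc(SCC(=O)N(Cc3ccc(OC)c(O)c3)c3cc(OC)c(OC)c(OC)c3)sc2c1`) gives 4110 nM. Compound 3 thus stands within the scatter of compound 2 and under the value of compound 1. Compound 4 (`COc1ccc(CN(C(=O)CSc2nc3c(C)cccc3s2)c2cc(OC)c(OC)c(OC)c2)cc1O`) carries 4-methyl-1,3-benzothiazol-2-yl in place of 6-methoxy-1,3-benzothiazol-2-yl on a sulfur. The measured change closest to this one is the methoxy gain, a 1.9-fold higher number from compound 2 to compound 3 (0.29 log units; within the scatter), which stays within the scatter. The hydroxy gain, a 4.0-fold lower number from compound 1 to compound 2 (0.60 log units; beyond the scatter), concerns a different group and bears on it little. No methyl group has been measured, so no step beyond the scatter is expected in this assay. The estimate amounts to a 1.4-fold lower number from compound 3 to compound 4 (0.14 log units; within the scatter). Compound 4 is estimated at 3000 nM, with an expected range from 1100 nM to 8500 nM.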

Compound 4, half-maximal inhibitory concentration: 12300 nM
Estimate against measurement, compound 4: 4.1-fold (0.61 log units) below; measured number above the stated range.
By their numbers in this assay, from the lowest: compounds 2 and 3 (each within the scatter of the next); then compounds 1 and 4 (each within the scatter of the next).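

In this assay, the group on the sulfur proves able to cost activity: 4-methyl-1,3-benzothiazol-2-yl in place of 6-methoxy-1,3-benzothiazol-2-yl gives a 3.0-fold higher number from compound 3 to compound 4 (0.48 log units; beyond the scatter). The methyl gain alone gives a 5.8-fold higher number from compound 2 to compound 4 (0.77 log units; beyond the scatter), a step beyond the scatter, whereas the methoxy gain had stayed within it, so the two substituents do not read alike here. No measured evidence on the compounds accounts for this result. The compounds shown leave open how an amine or a carboxylic acid on this group would read, and whether the loss follows the methyl itself or its place on the group.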